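This account rests on a few compounds, and the source may have more. Where it says the series, first, only, none or still open, it means among the compounds named here.

Compound 1 `CCOc1c(-c2cc(OC)c(OC)c(OC)c2)oc2ccccc2c1=O`: 900 nM
Compound 2 `CCCCOc1c(-c2cc(OC)c(OC)c(OC)c2)oc2ccccc2c1=O`: 12800 nM
Compound 3 `COc1cc(-c2oc3ccccc3c(=O)c2OC(C)C)cc(OC)c1OC`: 21200 nM

All three values come from a functional assay on PC-3 cells (Homo sapiens) for antiproliferative activity, read by WST assay, with a stated time of 3 days; on this read-out lower numbers stand for stronger inhibition and higher numbers for weaker inhibition. Compound 3 sits at the weak end, level with its nearest neighbour: a 1.7-fold higher number from compound 2 to compound 3 (0.22 log units; within the scatter). The gap to the other compound is large: a 24-fold higher number from compound 1 to compound 3 (1.37 log units; beyond the scatter).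

The next compound, compound 4 `CCN(CC)CCCCCOc1c(-c2cc(OC)c(OC)c(OC)c2)oc2ccccc2c1=O`, has 5-(diethylamino)pentyl in place of isopropyl on an oxygen on an aromatic ring.

Chain length alone offers no gain, as the large rise with the butyl chain of compound 2 shows: a 14-fold higher number from compound 1 to compound 2 (1.15 log units; beyond the scatter). Among the compounds with values here, no measured compound carries a nitrogen in its chain, so these steps guide only loosely. A moderate fall is tentatively expected: a 5.3-fold lower number from compound 3 to compound 4 (0.72 log units; beyond the scatter). For compound 4 the estimate is 4000 nM, with an expected range of 700 nM to 20000 nM.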

Compound 4, half-maximal inhibitory concentration: 6600 nM
Compound 4: the middle estimate sits 1.7-fold (0.22 log units) below what was measured; the range from low to high includes it.
By their numbers in this assay, from the lowest: compound 1; then compounds 4, 2 and 3 (each within the scatter of the next, the first and the last beyond it).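

At the oxygen on the aromatic ring, 5-(diethylamino)pentyl in place of isopropyl gives a modest gain (a 3.2-fold lower number from compound 3 to compound 4 (0.51 log units; beyond the scatter)), but the ethyl ether of compound 1 stays ahead (a 7.3-fold higher number from compound 1 to compound 4 (0.87 log units; beyond the scatter)). In this assay, the diethylamino-ended chain stands level with the butyl chain (a 1.9-fold lower number from compound 2 to compound 4 (0.29 log units; within the scatter)), so adding this amine end to a long chain brings no change beyond the scatter. Nothing measured here accounts for these differences.

Still open, going by these compounds, is how a propyl chain or a shorter diethylamino chain would compare with compound 1. Also open, on these data alone, is whether a morpholine at the chain end would read differently from diethylamino.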